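Octylsulfanyl in place of cyclopropylamino at the assay limit

The source may hold more compounds than are shown below. What is called first, only, known or untested is meant among the compounds shown, and "the series" means these compounds.

Compound 1 `CCOc1nc(N)nc2c1ncn2/C=C1/CC1(CO)CO` gives > 20000 nM in an ADME assay on MOLT-3 cells (Homo sapiens) for cytotoxicity, with a stated time of 7 days (on this read-out lower numbers stand for higher toxicity in this test and higher numbers for lower toxicity in this test), as a limit of the assay. Compound 2 `Nc1nc(NC2CC2)c2ncn(/C=C3/CC3(CO)CO)c2n1` gives > 20000 nM in this assay and this is likewise only a limit. Among the compounds with values here, the sole measured step that the two limits leave unreadable from compound 1 to compound 2 has no readable size and the limit of > 20000 nM in this assay, at which 2 of the 2 values shown sit, is all the series shows so far. Within the data shown here, compound 3 `CCCCCCCCSc1nc(N)nc2c1ncn2/C=C1/CC1(CO)CO` carries octylsulfanyl in place of cyclopropylamino on an aromatic carbon and no measured step gives the size of this change. A modest move toward higher toxicity is expected, and the estimated step of an at least 1.2-fold lower number from compound 2 to compound 3 (0.09 log units; that floor lies within the scatter) rests on no readable precedent. For compound 3 the expected value is 16000 nM with an estimated range of 5000 nM to 30000 nM and an outcome at the limit of the assay remains quite possible.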

Compound 3, half-maximal cytotoxic concentration: > 20000 nM
Compound 3: no number, only a limit; the forecaster's own chance of this, stated with the estimate: 55%; middle value at least 1.2-fold (0.09 log units) away from the limit.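

Compound 3 gives > 20000 nM in this assay, which is only a limit. Within the data shown here, no step from compound 1 or compound 2 to compound 3 can be read. Whether ethoxy, cyclopropylamino and octylsulfanyl differ at all in this assay stays open: the limit of > 20000 nM in this assay, at which 3 of the 3 values shown sit.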